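The source may hold more compounds than are shown below. What is called first, only, known or untested is meant among the compounds shown, and "the series" means these compounds.

Compound 2 `CC(C)NC(=S)SCC1=CCOC1=O` and compound 1 `CCNC(=S)SCC1=CCOC1=O` share one core and differ only at the amide-type nitrogen. In a functional assay on EC9706 cells (Homo sapiens) for antiproliferative activity, read by MTT assay, with a stated time of 72 h (on this read-out lower numbers stand for stronger inhibition and higher numbers for weaker inhibition), compound 1 gives 44400 nM and compound 2 gives 59400 nM, so compound 2 stands at the higher of the two numbers, a gap that a 1.3-fold higher number from compound 1 to compound 2 (0.13 log units; within the scatter) shows lies within the scatter. Compound 3 `O=C1OCC=C1CSC(=S)N1CCCC1` carries pyrrolidin-1-yl in place of isopropylamino on a thiocarbonyl carbon. Among the measured compounds shown here, no measured step bears directly on that change; the only step on record, a 1.3-fold higher number from compound 1 to compound 2 (0.13 log units; within the scatter), also altered the nitrogen substituent without moving the number beyond the scatter, so no step beyond the scatter is expected in this assay. Compound 3 is therefore expected to give 50000 nM, ranging from 15000 nM to 160000 nM. The expected step is a 1.2-fold lower number from compound 2 to compound 3 (0.07 log units; within the scatter).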

Compound 3, half-maximal inhibitory concentration: 14400 nM
Compound 3: the middle estimate sits 3.5-fold (0.54 log units) above what was measured; the measured number lies below the stated range.
By their numbers in this assay, from the lowest: compound 3; then compounds 1 and 2 (each within the scatter of the next).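

Unlike the earlier change from ethylamino to isopropylamino, the change on the thiocarbonyl carbon to pyrrolidin-1-yl moves the number in this assay beyond the scatter, giving a 4.1-fold lower number from compound 2 to compound 3 (0.62 log units; beyond the scatter) and also a 3.1-fold lower number from compound 1 to compound 3 (0.49 log units; beyond the scatter). This change closes a five-membered ring and also removes the hydrogen-bond donor, so two features change together. No available evidence explains the shift.

Which of these two features matters remains open. Diethylamino, which has no ring and no amide hydrogen, and piperidin-1-yl, with its six-membered ring, would help to separate them.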